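Swapping 4-chlorophenyl for 5-chloropyridin-2-yl on the sulfonyl sulfur

The source may hold more compounds than are shown below. What is called first, only, known or untested is meant among the compounds shown, and "the series" means these compounds.

Measured so far in an ADME assay on the whole organism (Rattus norvegicus, strain Sprague-Dawley), read by LC-MS; a lower number here means that the compound disappears faster, a higher number that the compound lasts longer (values by compound)
- compound 1 `N#Cc1ccc(S(=O)(=O)[C@H]2CN(S(=O)(=O)c3ccc(C#N)cc3Cl)C[C@@]2(O)CO)cc1` 1 h
- compound 2 `N#Cc1ccc(S(=O)(=O)N2C[C@H](S(=O)(=O)c3ccc(Cl)cc3)[C@](O)(CO)C2)c(Cl)c1` 1.6 h

Compound 2 (1.6 h) and compound 1 (1 h) lie within the scatter of each other, so neither stands apart on these numbers. Compound 3 `N#Cc1ccc(S(=O)(=O)N2C[C@H](S(=O)(=O)c3ccc(Cl)cn3)[C@](O)(CO)C2)c(Cl)c1` carries 5-chloropyridin-2-yl in place of 4-chlorophenyl on a sulfonyl sulfur. Going by the values given here, only one measured step is available, and it bears on this change only indirectly: chloro in place of cyano on an aromatic carbon (a 1.6-fold higher number from compound 1 to compound 2 (0.20 log units; within the scatter)), which stays within the scatter. Among the compounds with values here, no measured pair shows the exchange made here, so that small step is the only scale at hand. No step beyond the scatter is therefore expected, in either direction (a 1.1-fold lower number from compound 2 to compound 3 (0.06 log units; within the scatter)). In this assay the estimated value for compound 3 is 1.4 h (expected range 0.7 h to 2.8 h).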

Compound 3, mean residence time: 1.4 h
The estimate for compound 3 equals the measured number at the digits printed, and the stated range covers the measured number.
By their numbers in this assay, from the lowest: compounds 1, 3 and 2 (each within the scatter of the next).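

In this assay, the exchange on the sulfonyl sulfur whose other neighbour is a saturated ring carbon gives a 1.1-fold lower number from compound 2 to compound 3 (0.06 log units; within the scatter), so the ring nitrogen and the added hydrogen-bond acceptor of 5-chloropyridin-2-yl leave the read-out inside the scatter of the 4-chlorophenyl compound. The exchange against 4-cyanophenyl gives a 1.4-fold higher number from compound 1 to compound 3 (0.15 log units; within the scatter), so all three aromatic groups at this place now sit within the scatter of each other, and the series shows no separation among them. Nothing at hand says why these steps are so small.

No group shown at this place has yet moved the number beyond the scatter, so how strongly this position can influence residence time remains unknown. An amine or a carboxylic acid on this aromatic ring, or a longer chain in place of the ring, would test that.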